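A few compounds are considered here, and "the series" means these few. Any claim that something is new, unique, unknown or untested is made for them only; others in the source may bear on it.

In an ADME assay on BT-549 cells (Homo sapiens) for cytotoxicity, read by neutral red uptake, with a stated time of 48 h (on this read-out lower numbers stand for stronger inhibition and higher numbers for weaker inhibition), numbers exist so far for two compounds. Compound 1 `O=c1sc2ccccc2n1CCCCCCN1CCN(CCCCCCn2c(=O)sc3ccccc32)CC1` gives 24300 nM, and compound 2 `O=c1sc2ccccc2n1CCCCCCN1CCN(CCCn2c(=O)sc3ccccc32)CC1` gives 25000 nM. These two values lie within the usual scatter of repeated measurements, so compound 2 stands level with compound 1, and neither can be called the stronger inhibitor.

The next compound, compound 3 `O=c1sc2ccccc2n1CCCCCCN1CCN(CCCCn2c(=O)sc3ccccc32)CC1`, differs from compound 2 in one place: a group of 11 heavy atoms (8 carbon, 1 nitrogen, 1 oxygen, 1 sulfur; one five-membered aromatic ring with 2 hetero atoms, one six-membered aromatic ring of carbon only) in place of a group of 10 heavy atoms (7 carbon, 1 nitrogen, 1 oxygen, 1 sulfur; one five-membered aromatic ring with 2 hetero atoms, one six-membered aromatic ring of carbon only), on a saturated chain carbon, three bonds along the chain from an amine nitrogen in a ring. The swap sits on a saturated chain carbon, three bonds along the chain from an amine nitrogen in a ring. Both the group that leaves and the group that enters carry one five-membered aromatic ring with 2 hetero atoms and one six-membered aromatic ring of carbon only.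

No measured step shows what this kind of change does, so the expectation rests on the two values alone, and these offer no reason to favour either direction in this assay. The estimated step, no change at the digits printed from compound 2 to compound 3 (within the scatter), is expected to stay within the scatter. Compound 3 is estimated at 25000 nM, with an expected range of 14000 nM to 42000 nM.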

Compound 3, half-maximal inhibitory concentration: 21300 nM
The estimate for compound 3 lay 1.2-fold (0.07 log units) above the measured number; low and high end bracket the measured number.
By their numbers in this assay, from the lowest: compounds 3, 1 and 2 (each within the scatter of the next).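

In this assay, a group of 11 heavy atoms in place of a group of 10 heavy atoms, on a saturated chain carbon, three bonds along the chain from an amine nitrogen in a ring, gives a 1.2-fold lower number from compound 2 to compound 3 (0.07 log units; within the scatter), while a group of 10 heavy atoms in place of a group of 12 heavy atoms, on a saturated chain carbon, four bonds along the chain from an amine nitrogen in a ring, gives a 1.1-fold lower number from compound 1 to compound 3 (0.06 log units; within the scatter). Both steps lie within the scatter, so the three compounds stand level, and among these three groups, which carry the same two aromatic rings, heavy-atom count does not separate the compounds in this read-out. Nothing measured here offers an explanation for this flat result.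

The compounds shown leave open whether this level picture would hold for a much shorter or a much longer chain. They also leave open what an added amine or a carboxylic acid on the chain would do to the number.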